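Cyano in place of chloro on a benzamide sulfonamide

This account rests on a few compounds, and the source may have more. Where it says the series, first, only, none or still open, it means among the compounds named here.

Measured so far:
compound 1 `COc1cc(NC(=O)c2ccc(C#N)cc2)ccc1NS(=O)(=O)C(F)(F)F` — > 250000 nM in an ADME assay on HEK293 cells (Homo sapiens) for cytotoxicity, read by MTT assay, with a stated time of 48 h (on this read-out higher numbers stand for weaker inhibition and lower numbers for stronger inhibition), a limit
compound 2 `CS(=O)(=O)Nc1ccc(NC(=O)c2ccc(C#N)cc2)cc1F` — > 250000 nM in this assay, a limit
compound 3 `O=C(Nc1ccc(NS(=O)(=O)C(F)(F)F)c(F)c1)c1ccc(Cl)cc1` — 79000 nM in this assay

Of the compounds shown here, three have been tested in this assay. Compound 1 gives > 250000 nM, which is a limit of the assay and not a number. Compound 2 gives > 250000 nM, again a limit rather than a number. Among the measured compounds shown here, compound 3 gives 79000 nM, the only number among the three; the other two values sit at the limit of > 250000 nM in this assay, at which 2 of the 3 values shown sit.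

Compound 4 `N#Cc1ccc(C(=O)Nc2ccc(NS(=O)(=O)C(F)(F)F)c(F)c2)cc1` has not yet been measured. It differs from compound 3 in one place: cyano in place of chloro on an aromatic carbon. For the measured compounds named here, no measured pair in this set shows this change on its own, so its size must be guessed. Compounds 1 and 2, which also carry a cyano group, both stop at the limit, while compound 3 with chloro gives a number.

For compound 4 the step of a 2.5-fold higher number from compound 3 to compound 4 (0.40 log units; beyond the scatter) is expected to go toward weaker inhibition, beyond the usual scatter, with a fair chance of reaching the limit. Compound 4 is therefore estimated at 200000 nM, with a range from 60000 nM to 700000 nM.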

Compound 4, half-maximal inhibitory concentration: > 250000 nM
Compound 4: a limit, no number; the forecaster's own chance of this, stated with the estimate: 55%; middle value at least 1.2-fold (0.09 log units) away from the limit.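

In this assay, among the compounds shown here, the change from 4-chlorophenyl to 4-cyanophenyl gives an at least 3.1-fold higher number from compound 3 to compound 4 (0.50 log units; beyond the scatter), the first view of this swap on its own, at this position on the otherwise unchanged compound 3. Compound 4 gives > 250000 nM, which is a limit of the assay and not a number. With this result, all three compounds shown that carry cyano sit at the same limit, and compound 3, the only one with chloro, is the only one that gives a number: the limit of > 250000 nM in this assay, at which 3 of the 4 values shown sit.

The steps to compound 4 from compound 1 and from compound 2 cannot be read, as each joins two limits, so fluoro in place of methoxy and trifluoromethyl in place of methyl have no size here. The compounds shown also leave open how far the value of compound 4 lies past the limit, and whether a group such as an amine or a carboxylic acid in place of the chloro would also give a higher number in this assay or whether this step is particular to cyano.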